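The source may hold more compounds than are shown below. What is called first, only, known or untested is meant among the compounds shown, and "the series" means these compounds.

These notes follow the series as read in an ADME assay for permeability, using PAMPA, at pH 7.4; on this read-out higher numbers stand for higher permeability and lower numbers for lower permeability. Of the compounds shown here, three have numbers so far. Compound 1 (`O=C(Nc1ccc(F)c(-c2nc3ccccc3o2)c1)c1cc([N+](=O)[O-])ccc1Cl`) gives 366 10^-6 cm/s, the highest of the three. Compound 3 (`O=C(Nc1nc2ccc(Cl)cc2s1)c1cc([N+](=O)[O-])ccc1Cl`) gives 138 10^-6 cm/s, and compound 2 (`Cc1ccc(-c2nc3ccccc3s2)cc1NC(=O)c1cc([N+](=O)[O-])c(N2CCC(C(=O)O)CC2)cc1Cl`) gives 17 10^-6 cm/s. Both lie lower than compound 1 by more than the usual scatter. No two of these compounds differ in one place only, so the data hold no measured step for any single change, and the gaps among them cannot be assigned to any one group.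

The next compound is compound 4 (`O=C(Nc1ccc(F)c(-c2nc3ccccc3s2)c1)c1cc([N+](=O)[O-])ccc1Cl`), which departs from compound 1 by a single exchange: 1,3-benzothiazol-2-yl in place of 1,3-benzoxazol-2-yl on an aromatic carbon. In words, this is 1,3-benzothiazol-2-yl in place of 1,3-benzoxazol-2-yl on an aromatic carbon, ortho to a fluoro group and meta to a large group; the rest of the structure is unchanged.

Among the measured compounds shown here, with no measured precedent for this exchange, no step beyond the scatter is expected in this assay, and any drift is expected to be downward because compound 1 stands at 366 10^-6 cm/s, the top of the three numbers. The expected change is a 1.3-fold lower number from compound 1 to compound 4 (0.10 log units; within the scatter), an estimate within the scatter. For compound 4 the estimated value is 290 10^-6 cm/s, with an expected range from 130 10^-6 cm/s to 600 10^-6 cm/s.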

Compound 4, apparent permeability: 17 10^-6 cm/s
Estimate against measurement, compound 4: 17-fold (1.23 log units) above; the whole stated range lies above it.
By their numbers in this assay, from the lowest: compounds 2 and 4 (each within the scatter of the next); then compound 3; then compound 1.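

The series now has one measured step for a single change: in this assay, 1,3-benzothiazol-2-yl in place of 1,3-benzoxazol-2-yl gives a 22-fold lower number from compound 1 to compound 4 (1.33 log units; beyond the scatter). This place, on an aromatic carbon ortho to a fluoro group and meta to a large group, is therefore highly sensitive to the exchange, even though the two groups have the same ring types, the same heavy-atom count, the same hydrogen-bond donor and acceptor counts and no net charge, and differ only in sulfur standing for oxygen. Nothing measured here accounts for a step of this size.

This single pair cannot show whether the step is specific to this exchange or would recur with other groups at this place, such as an unfused phenyl ring or a 1,3-benzoxazol-2-yl bearing a methoxy group. It also leaves open whether the step keeps its size when the neighbouring fluoro group gives way to a chloro group or an amine, or when the rest of the structure differs from that of compound 1.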